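Replacing the Fluorophenyl Sulfonamide With a Methoxyphenyl

A few compounds are considered here, and "the series" means these few. Any claim that something is new, unique, unknown or untested is made for them only; others in the source may bear on it.

Compound 2 `Cc1ccccc1C(=O)c1cnc(NCCCNS(=O)(=O)c2ccc(F)cc2)s1` gives 9900 nM in an assay on isolated protein for inhibition of Neuropeptide Y receptor type 5 (Mus musculus) (on this read-out lower numbers stand for stronger inhibition and higher numbers for weaker inhibition), the higher of the two numbers recorded. Compound 1 `Cc1ccccc1C(=O)c1cnc(NCCCNS(=O)(=O)c2cccc(F)c2)s1` gives 5.5 nM. For the measured compounds named here, the only measured step, a 1800-fold higher number from compound 1 to compound 2 (3.26 log units; beyond the scatter), bears on compound 3 `COc1cccc(S(=O)(=O)NCCCNc2ncc(C(=O)c3ccccc3C)s2)c1`, which differs from compound 2 by 3-methoxyphenyl in place of 4-fluorophenyl on a sulfonyl sulfur. Going by these compounds, the incoming 3-methoxyphenyl resembles the 3-fluorophenyl of compound 1 more than the 4-fluorophenyl of compound 2, though a methoxy group is untested here. The step is therefore expected to be large and downward, about a 330-fold lower number from compound 2 to compound 3 (2.52 log units; beyond the scatter). Compound 3 is estimated at 30 nM, within 4 nM to 600 nM.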

Compound 3, half-maximal inhibitory concentration: 11 nM
Beside the measured number, compound 3's estimate is 2.7-fold (0.44 log units) above it; the measured number falls inside the stated range.
By their numbers in this assay, from the lowest: compounds 1 and 3 (each within the scatter of the next); then compound 2.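

In this assay, the 3-methoxyphenyl on the sulfonyl sulfur gives a 900-fold lower number from compound 2 to compound 3 (2.95 log units; beyond the scatter), showing that the 4-fluorophenyl result does not extend to this group. Methoxy in place of fluoro on an aromatic carbon leaves a 2.0-fold higher number from compound 1 to compound 3 (0.30 log units; within the scatter), so compound 1 and compound 3 cannot be told apart here. No supporting measurement accounts for either step. Going by these compounds, whether a 4-methoxyphenyl would match the 4-fluorophenyl of compound 2 remains open. So does how an unsubstituted phenyl or a 3-aminophenyl would compare on the same sulfonyl sulfur.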